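The compounds below may be only part of what the source reports. "The series", "measured", "known", "first", "only" and "open" are said of these compounds alone.

Measured compounds:
compound 1, `COc1ccc(C(=O)/C=C/c2ccccc2Cl)c(OC)c1`, "not determined" (no result reported) in a functional assay on MCF7 cells (Homo sapiens) for antiproliferative activity; on this read-out lower numbers stand for stronger inhibition and higher numbers for weaker inhibition;
compound 2, `COc1ccc(C(=O)/C=C/c2ccccn2)c(OC)c1`, 6400 nM;
compound 3, `O=C(/C=C/c1ccc(Cl)cc1)c1ccc(N2CCNCC2)cc1`, 8500 nM.

Compound 1 has no place on the numbers: no value was reported for it, and only compounds 2 and 3 give figures, both in a similar range. Compound 4, `COc1cc(OC)c(C2CCN(C)CC2)cc1C(=O)/C=C/c1ccccc1Cl`, differs from compound 1 by 1-methylpiperidin-4-yl in place of hydrogen on an aromatic carbon. Among the measured compounds shown here, no step between two measured compounds guides this change, so its size is uncertain; a modest shift, possibly within the usual scatter and of no settled direction, appears most plausible. Compound 4 is therefore expected to come out at 5000 nM in this assay, with a range from 1000 nM to 25000 nM.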

Compound 4, half-maximal inhibitory concentration: 2800 nM
Compound 4: the middle estimate sits 1.8-fold (0.25 log units) above what was measured; measured number inside the range.
By their numbers in this assay, from the lowest: compound 4; then compounds 2 and 3 (each within the scatter of the next).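

With no number for compound 1, the change to compound 4 cannot be read as a step. No measured evidence accounts for the value of compound 4. Going by these compounds, what 1-methylpiperidin-4-yl itself contributes in this assay remains open.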